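The source may hold more compounds than are shown below. What is called first, only, known or untested is meant among the compounds shown, and "the series" means these compounds.

Within the data shown here, in a functional assay on the whole organism (strain Sprague-Dawley) for inhibition, with Rattus norvegicus as the target, with a stated time of 10 min (on this read-out higher numbers stand for an effect only at larger amounts of compound and lower numbers for an effect already at smaller amounts), compound 1 `CCOc1ccccc1-c1ncc(C(=O)O)c(=O)[nH]1` gives 0.5 mg/kg, and compound 2 `C=CCOc1ccccc1-c1ncc(C(=O)O)c(=O)[nH]1` gives 0.5 mg/kg, so compound 1 stands level with the only other measured compound. Compound 3 `CCOc1ccc(N)cc1-c1ncc(C(=O)O)c(=O)[nH]1` has not yet been measured in this assay. Its structure departs from that of compound 1 as follows: amino in place of hydrogen on an aromatic carbon. The change is therefore amino in place of hydrogen on an aromatic carbon, para to the ethoxy group.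

Among the measured compounds shown here, only one measured step is available, no change at the digits printed from compound 1 to compound 2 (within the scatter), which lies within the scatter. That step swaps methyl for vinyl on a saturated chain carbon bound to an oxygen, so it says nothing directly about a new group on the aromatic carbon. For the measured compounds named here, no measured compound carries any group at that place, and the direction of the step remains uncertain. A small move toward larger doses is expected, estimated as a 2.0-fold higher number from compound 1 to compound 3 (0.30 log units; within the scatter), though no change beyond the scatter is also plausible. For compound 3 the expected value is 1 mg/kg, with an estimated range of 0.2 mg/kg to 5 mg/kg.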

Compound 3, dose for 50% inhibition: 1.2 mg/kg
Compound 3: the middle estimate sits 1.2-fold (0.08 log units) below what was measured; the range from low to high includes it.
By their numbers in this assay, from the lowest: compounds 1 and 2 (each within the scatter of the next); then compound 3.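

In this assay, the change to the aromatic carbon para to an ethoxy group is the first among these compounds to give a step beyond the scatter: amino in place of hydrogen gives a 2.4-fold higher number from compound 1 to compound 3 (0.38 log units; beyond the scatter) and so shifts the read-out toward larger doses, whereas the alteration of the ethoxy chain gave no change at the digits printed from compound 1 to compound 2 (within the scatter) and left the printed number where it stood. The step is modest, and compound 3 gives 1.2 mg/kg with the amino group in place, so this aromatic carbon accepts that group with only a limited cost on this read-out. No measurement shown here accounts for the shift.

On these data alone, it remains open whether this cost belongs to the amino group itself or to any group at this carbon, which a hydroxyl, a methyl or a fluorine at the same place would help to separate. As far as these compounds go, it is also open whether an acetylated amine at this carbon would give a different number, and whether the allyloxy chain of compound 2 would respond to the amino group as the ethoxy group of compound 1 does.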